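This account rests on a few compounds, and the source may have more. Where it says the series, first, only, none or still open, it means among the compounds named here.

Three compounds have a number or a limit in an assay on CHO cells for displacement of a labelled ligand from prostaglandin E2 receptor EP1 subtype (Homo sapiens); on this read-out higher numbers stand for weaker inhibition and lower numbers for stronger inhibition:

- compound 1 `CCc1ccccc1N(Cc1nnc(Cc2ccc(OC)cc2)o1)S(=O)(=O)c1ccc(C)cc1`: 126 nM; 126 nM (2 entries)
- compound 2 `CCOc1ccc(Cc2nnc(CN(c3ccccc3CC)S(=O)(=O)c3ccc(C)cc3)o2)cc1`: 126 nM
- compound 3 `CCc1ccccc1N(Cc1nnc(Oc2ccc(OC)cc2)o1)S(=O)(=O)c1ccc(C)cc1`: < 1000 nM

Compound 1 and compound 2 sit within the usual scatter of each other, so nothing separates them. Compound 3 stands apart: its entry is only a limit, (the limit of < 1000 nM in this assay, at which 1 of the 3 values shown sits), and a second entry for compound 3 also gives no single number. For that reason the step that the limit leaves unreadable from compound 2 to compound 3 cannot be read; its size is unknown.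

The next compound, compound 4 `CCc1ccccc1N(Cc1nnc(COc2ccc(OC)cc2)o1)S(=O)(=O)c1ccc(C)cc1`, is reached by a single change: (4-methoxyphenoxy)methyl in place of 4-methoxyphenoxy on an aromatic carbon. In plain terms a one-carbon link is inserted between the shared core and the aryl ether, so the side group of compound 4 resembles in length the methoxybenzyl of compound 1.

Among the measured compounds shown here, no measured step bears directly on this change, since the only one touching compound 3 is unreadable. The expected step that the limit leaves unreadable from compound 3 to compound 4 therefore cannot be anchored on a measured number for compound 3. The expectation for compound 4 rests instead on compound 1, because compound 1 with a side group of similar length gives 126 nM; 126 nM (2 entries). Compound 4 is estimated at 200 nM, within a range from 50 nM to 800 nM.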

Compound 4, half-maximal inhibitory concentration: 25.1 nM
Estimate against measurement, compound 4: 8.0-fold (0.90 log units) above; measured number below the stated range.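

At this position, on an aromatic carbon of the five-membered aromatic ring, a (4-methoxyphenoxy)methyl side group gives a 5.0-fold lower number from compound 2 to compound 4 (0.70 log units; beyond the scatter) in this assay, a modest step but one that lies beyond the scatter. Compound 1 and compound 2 could not be separated from each other, so this is the first change in the series shown that moves the number by a readable amount, and it shows that the side group at this position need not be a benzyl group to keep a low number. Compound 3 has only a limit, < 1000 nM, so neither step that involves it can be read and the effect of the inserted one-carbon link has no size: the limit of < 1000 nM in this assay, at which 1 of the 4 values shown sits.

The compounds shown leave open how a longer chain in the link, or an amine in place of the ether oxygen of the link, would read in this assay. They also leave open whether the number of compound 4 depends on the methoxy group on its aromatic ring, since no other group at that place appears with this link.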